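Furan-2-yl for Methoxynaphthyl: an Expected Drop

The source may hold more compounds than are shown below. What is called first, only, known or untested is meant among the compounds shown, and "the series" means these compounds.

Compound 1 `N#CC1=C(N)N(c2ccc(S(N)(=O)=O)cc2)C2=C(C(=O)CCC2)C1c1c(O)ccc2ccccc12`: 0%
Compound 2 `COc1ccc2ccccc2c1C1C(C#N)=C(N)N(c2ccc(S(N)(=O)=O)cc2)C2=C1C(=O)CCC2`: 62%

In a functional assay on Ehrlich cells (Mus musculus) for antiproliferative activity, read by trypan blue exclusion, with a stated time of 2 h, tested at 25 ug/mL (on this read-out lower numbers stand for a weaker effect and higher numbers for a stronger effect at the one concentration tested), compound 2 stands highest of the two numbers, with compound 1 nearest and lower beyond the scatter. Among the measured compounds shown here, the only measured step, a number 62 percentage points higher from compound 1 to compound 2 (beyond the scatter), was large. Compound 3 `N#CC1=C(N)N(c2ccc(S(N)(=O)=O)cc2)C2=C(C(=O)CCC2)C1c1ccco1` differs from compound 2 by furan-2-yl in place of 2-methoxynaphthalen-1-yl on a saturated ring carbon. For the measured compounds named here, that earlier step bears on it only loosely: the methyl whose arrival came with the large gain now leaves together with the whole 2-methoxynaphthalen-1-yl, and no measured step covers such an exchange. A fall beyond the scatter is therefore expected, with wide uncertainty. Compound 3 is estimated at 25%, between 0% and 60%, an expected step of a number 37 percentage points lower from compound 2 to compound 3 (beyond the scatter).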

Compound 3, a percentage reported as activity, at one concentration (the size of the read-out at that concentration, not a potency): 0%
Compound 3: middle estimate off by 25 percentage points, on the high side; the measured number falls inside the stated range.
By their numbers in this assay, from the lowest: compounds 1 and 3 (each within the scatter of the next); then compound 2.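

In this assay, a methyl on the oxygen is not enough on its own to give activity at this saturated ring carbon: the group carrying it matters too, with a number 62 percentage points lower from compound 2 to compound 3 (beyond the scatter) when furan-2-yl enters. Furan-2-yl and 2-hydroxynaphthalen-1-yl cannot be told apart here, with no change at the digits printed from compound 1 to compound 3 (within the scatter) in this read-out. Nothing measured here explains the loss.

As far as these compounds go, whether the activity of compound 2 needs the methoxy group, the two fused aromatic rings, or both remains open. A 2-methoxyphenyl or a plain naphthalen-1-yl at this carbon would separate those two parts.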